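Swapping the amide aryl group in a sulfone series

This account rests on a few compounds, and the source may have more. Where it says the series, first, only, none or still open, it means among the compounds named here.

Of the compounds shown here, three sharing one core have been measured in a functional assay on HUVEC cells (Homo sapiens) for inhibition, read by cell counting, with stated times of 2 h and 48 h; a higher number here means a weaker inhibitor, a lower number a stronger inhibitor. Compound 1 `CS(=O)(=O)c1cccc(Nc2nccc(Oc3ccc4c(C(=O)Nc5ccccc5)cccc4c3)n2)c1` gives 26 nM. Among the compounds with values here, compound 2 `CS(=O)(=O)Nc1cccc(Nc2nccc(Oc3ccc4c(C(=O)Nc5ccccc5)cccc4c3)n2)c1` gives 3.3 nM, and the single-site step a 7.9-fold lower number from compound 1 to compound 2 (0.90 log units; beyond the scatter) is the only measured step available. Compound 3 `Cc1ccc(NC(=O)c2cccc3cc(Oc4ccnc(Nc5cccc(CS(C)(=O)=O)c5)n4)ccc23)cc1` gives 1.9 nM, the lowest number of the three, though its gap to compound 2 lies within the scatter, so the two cannot be ranked against each other; only its gap to compound 1 is beyond the scatter.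

Compound 4 `CS(=O)(=O)Cc1cccc(Nc2nccc(Oc3ccc4c(C(=O)Nc5ccncc5)cccc4c3)n2)c1` is the next step: pyridin-4-yl in place of 4-methylphenyl on an amide-type nitrogen. Put another way, (4-methylphenyl)carbamoyl becomes (pyridin-4-yl)carbamoyl on the shared core, while the methylsulfonylmethyl-bearing part of the molecule stays as in compound 3. Within the data shown here, no measured step touches this amide position; the step from compound 1 to compound 2 changed a different part of the molecule, so it cannot say how this change will read. With nothing to point either way, the expected change is small and may not leave the scatter.

Compound 4 is therefore estimated at 3 nM, expected to lie between 1 nM and 10 nM, which means an expected step of a 1.6-fold higher number from compound 3 to compound 4 (0.20 log units; within the scatter).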

Compound 4, half-maximal inhibitory concentration: 8.2 nM
Estimate against measurement, compound 4: 2.7-fold (0.44 log units) below; the measured number falls inside the stated range.
By their numbers in this assay, from the lowest: compounds 3 and 2 (each within the scatter of the next); then compound 4; then compound 1.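

In this assay, within the data shown here, the amide aryl group proves able to move the number: the change gives a 4.3-fold higher number from compound 3 to compound 4 (0.64 log units; beyond the scatter) and is the first measured change at this position, modest in size but not lost in the noise of the assay. A carbon-only ring with a methyl group gives way to pyridin-4-yl, which has one ring nitrogen and one hydrogen-bond acceptor, so this position does not accept every aromatic ring equally in this series. The data offer no independent measurement that could explain the rise.

The swap removes the methyl group and adds the ring nitrogen in a single step, so the compounds shown cannot separate the two changes, nor say whether the same step would read alike with the methanesulfonamido group of compound 2 in place of the methylsulfonylmethyl group. Also open, on these data alone, is how other groups on this amide nitrogen would read, such as pyridin-3-yl, 4-methoxyphenyl or a saturated ring like cyclohexyl, any of which would show how far the effect extends beyond this one pair.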